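From compound 2 to compound 3: a ring change

This account rests on a few compounds, and the source may have more. Where it says the series, first, only, none or still open, it means among the compounds named here.

Compound 1 `Cc1nc(N)sc1CCCNC(=N)NC(=O)C[C@@H](C)c1ccccc1` and compound 2 `Cc1nc(N)sc1CCCNC(=N)NC(=O)CC(C)c1ccccc1` have the same atoms and bonds. In an in vitro functional assay on Sf9 cells for agonist activity at histamine H2 receptor (Cavia porcellus), read by GTPgammaS binding (a lower number here means that less compound is needed, a higher number that more compound is needed for the effect), compound 1 gives 17 nM and compound 2 gives 22.4 nM. The step of a 1.3-fold higher number from compound 1 to compound 2 (0.12 log units; within the scatter) rests on (the fact that one of compounds 1 and 2 is drawn with a defined configuration and the other without, at the place where they differ). On these two numbers compound 2 sits alongside compound 1, separated only by a step within the scatter. Compound 3 `Cc1nc(N)sc1CCCNC(=N)NC(=O)C[C@@H](C)C1CCCCC1` differs from compound 2 by 1-cyclohexylethyl in place of 1-phenylethyl on a saturated chain carbon bound to a carbonyl carbon. Within the data shown here, no measured step touches this group, so the one within-scatter step is the only guide. The estimate for compound 3 in this assay is 30 nM, within 8 nM to 120 nM. A step of a 1.3-fold higher number from compound 2 to compound 3 (0.13 log units; within the scatter) is thus expected, not clearly beyond the scatter.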

Compound 3, half-maximal effective concentration: 13.2 nM
Compound 3: middle estimate off by 2.3-fold (0.36 log units), on the high side, within the range that was stated.
By their numbers in this assay, from the lowest: compounds 3, 1 and 2 (each within the scatter of the next).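

Replacing the aromatic ring with a saturated one does not move the number in this assay beyond the scatter, with a 1.3-fold lower number from compound 1 to compound 3 (0.11 log units; within the scatter) and a 1.7-fold lower number from compound 2 to compound 3 (0.23 log units; within the scatter). At this position, a six-membered non-aromatic ring of carbon only therefore matches a six-membered aromatic ring of carbon only in these compounds. Nothing available bears on the reason for this match.

The compounds shown leave open how a piperidine ring, a cyclopentyl ring or an open hexyl chain would fare at this place. They also leave open what the opposite configuration at the stereocentre would give.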